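Working notes: bromo in place of hydroxy

A few compounds are considered here, and "the series" means these few. Any claim that something is new, unique, unknown or untested is made for them only; others in the source may bear on it.

compound 1 `CC1(C)[C@H]2CC[C@]1(C)N(Cc1cn(-c3ccccc3O)nn1)C(=O)C2` gives 120 nM
compound 2 `CC1(C)[C@H]2CC[C@]1(C)N(Cc1cn(-c3cccc(O)c3)nn1)C(=O)C2` gives 70 nM

In a functional assay on HepG2 cells (Homo sapiens) for inhibition, read by MTT assay, with a stated time of 24 h (on this read-out higher numbers stand for weaker inhibition and lower numbers for stronger inhibition), compound 2 stands at 70 nM within the scatter of compound 1, and neither number can be ranked above the other. Compound 3 `CC1(C)[C@H]2CC[C@]1(C)N(Cc1cn(-c3cccc(Br)c3)nn1)C(=O)C2` carries bromo in place of hydroxy on an aromatic carbon and has not yet been measured. Among the compounds with values here, the one measured step of a 1.7-fold lower number from compound 1 to compound 2 (0.23 log units; within the scatter) bears only indirectly: it exchanges 2-hydroxyphenyl for 3-hydroxyphenyl and removes no hydroxy. No direction can be read from the data, and the expected step of a 1.1-fold higher number from compound 2 to compound 3 (0.06 log units; within the scatter) in this assay is none beyond the scatter. Compound 3 is estimated at 80 nM with an expected range from 25 nM to 250 nM in these notes.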

Compound 3, half-maximal inhibitory concentration: 20 nM
For compound 3 the middle estimate is 4.0-fold (0.60 log units) above the measured one; the measured number lies below the stated range.
By their numbers in this assay, from the lowest: compound 3; then compounds 2 and 1 (each within the scatter of the next).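

Bromo in place of hydroxy on this aromatic carbon gives a 3.5-fold lower number from compound 2 to compound 3 (0.54 log units; beyond the scatter) in this assay and is the first change in the series to move the number beyond the scatter. 3-Bromophenyl in place of 2-hydroxyphenyl gives a 6.0-fold lower number from compound 1 to compound 3 (0.78 log units; beyond the scatter) and leaves compound 3 with the lowest number of the three. Nothing measured here accounts for the drop.

From the compounds shown here alone, whether the step comes from losing hydroxy or from gaining bromo stays open. A plain phenyl, chloro or an amine at this place would separate the two.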